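Swapping the aryl group on the shared core

The source may report more compounds than this note shows. Statements on the series, on what has been measured and on what is new or still open speak of the compounds shown alone.

In a functional assay on RPMI-8226 cells (Homo sapiens) for inhibition, read by sulforhodamine B assay, with a stated time of 48 h, tested at 10 uM (a higher number here means more inhibition at the concentration tested (going by the name of the read-out), a lower number less inhibition), compound 1 `COc1ccc(-c2cn3ccnc3c(-c3ccc4ncn(C5CCCCC5)c4c3)n2)cc1` gives 95.6%, while compound 2 `Clc1ccc(-c2cn3ccnc3c(-c3ccc4ncn(C5CCCCC5)c4c3)n2)cc1` gives 19%, the lowest of the two numbers; the step of a number 76.6 percentage points lower from compound 1 to compound 2 (beyond the scatter) is large. Compound 3 `c1csc(-c2cn3ccnc3c(-c3ccc4ncn(C5CCCCC5)c4c3)n2)c1` differs from compound 2 by thiophen-2-yl in place of 4-chlorophenyl on an aromatic carbon. Among the compounds with values here, only the step from compound 1 to compound 2 bears on this change, and it shows that the group at this place moves the read-out strongly. A rise is therefore expected, estimated as a number 31 percentage points higher from compound 2 to compound 3 (beyond the scatter), though with wide uncertainty. Compound 3 is expected to give about 50%, within a range from 15% to 90%.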

Compound 3, a percentage reported as inhibition, at one concentration (the size of the read-out at that concentration, not a potency): 52.3%
For compound 3 the middle estimate is 2.3 percentage points below the measured one; low and high end bracket the measured number.
By their numbers in this assay, from the lowest: compound 2; then compound 3; then compound 1.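

The thiophen-2-yl group gives a number 33.3 percentage points higher from compound 2 to compound 3 (beyond the scatter) and a number 43.3 percentage points lower from compound 1 to compound 3 (beyond the scatter) in this assay and so places a five-membered aromatic ring between the two substituted phenyl groups. The three aryl groups at this place thus give three separate levels, with 4-methoxyphenyl highest and 4-chlorophenyl lowest. Nothing available explains this order.

The compounds shown leave open whether an amine, a carboxylic acid or a longer alkoxy chain on the phenyl ring would keep the level of compound 1. They also leave open whether any aromatic ring is needed at this place.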